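The compounds below may be only part of what the source reports. "The series", "measured", "known", "first", "only" and "open" are said of these compounds alone.

Values in a functional assay on NCI-H522 cells (Homo sapiens) for inhibition, read by colorimetric assay and sulforhodamine B assay, with a stated time of 48 h; a lower number here means a stronger inhibitor of growth, a higher number a weaker inhibitor of growth:
- Compound 1 `CCCCCCCCCCCC[C@@H](O)[C@H]1CC[C@H]([C@H](O)CCCCCCCCCCNC(=O)c2ccco2)O1`: 18200 nM
- Compound 2 `CCCCCCCCCCCC[C@@H](O)[C@H]1CC[C@H]([C@H](O)CCCCCCCCCCNC(=O)c2ccsc2)O1`: 1000 nM
- Compound 3 `CCCCCCCCCCCC[C@@H](O)[C@H]1CC[C@H]([C@H](O)CCCCCCCCCCNC(=O)c2ccnn2C)O1`: not yet measured

Compound 2 holds the lower of the two numbers. The next change is 1-methyl-1H-pyrazol-5-yl in place of thiophen-3-yl on a carbonyl carbon. Going by the values given here, one measured step bears on it, an 18-fold lower number from compound 1 to compound 2 (1.26 log units; beyond the scatter), which is large, beyond the scatter, and also a ring exchange on a carbonyl carbon. Two compounds give no trend, but a sizeable move is plausible, and a higher number is expected, an estimated 5.0-fold higher number from compound 2 to compound 3 (0.70 log units; beyond the scatter). For compound 3 the expected value is 5000 nM, with an estimated range of 1200 nM to 20000 nM.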

Compound 3, concentration for 50% growth inhibition: 1410 nM
Compound 3: the middle estimate sits 3.5-fold (0.55 log units) above what was measured; measured number inside the range.
By their numbers in this assay, from the lowest: compounds 2 and 3 (each within the scatter of the next); then compound 1.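

In this assay, 1-methyl-1H-pyrazol-5-yl and thiophen-3-yl on the carbonyl carbon cannot be told apart, with a 1.4-fold higher number from compound 2 to compound 3 (0.15 log units; within the scatter) and so a sulfur ring and a two-nitrogen ring reading alike at this place. Furan-2-yl remains the outlier of the three, with a 13-fold lower number from compound 1 to compound 3 (1.11 log units; beyond the scatter) as a second large step alongside the one to compound 2. No measured evidence accounts for these differences.

Open, from the compounds shown here alone, is whether a six-membered ring such as phenyl or pyridin-3-yl on the same carbonyl carbon fits with compounds 2 and 3. Also open, going by these compounds, is whether furan-3-yl would read like furan-2-yl.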